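This account rests on a few compounds, and the source may have more. Where it says the series, first, only, none or still open, it means among the compounds named here.

Working notes on the series built around the shared core of compound 1 `O=C(NCCCOc1ccc2nc(O)ccc2c1)N(C1CC1)[C@@H]1CCC[C@H]1O`, followed in a functional assay on the whole organism for inhibition, with Mus musculus as the target, at a dose of 30 mg/kg by the oral route (on this read-out higher numbers stand for more inhibition at the one dose given (going by the name of the read-out) and lower numbers for less inhibition), where compound 1 gives 67%. Compound 2 `O=C(NCCCOc1ccc2nc(O)ccc2c1)N(C1CCCCC1)[C@H]1CCCC[C@@H]1O` gives 57% in this assay; the two numbers lie within the scatter of each other, so neither stands apart. Going by the values given here, no pair of measured compounds differs in one place only. Compound 3 `O=C(NCCCOc1ccc2nc(O)ccc2c1)N(C1CC1)[C@H]1CCCC[C@H]1O` differs from compound 1 by 2-hydroxycyclohexyl in place of 2-hydroxycyclopentyl on an amide-type nitrogen. Among the compounds with values here, no measured pair isolates this change; compound 2 already carries 2-hydroxycyclohexyl beside a cyclohexyl group. The step of a number 7 percentage points lower from compound 1 to compound 3 (within the scatter) is expected to be small, not beyond the scatter. Compound 3 is expected to give 60%, within 42% to 76%.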

Compound 3, a percentage reported as inhibition, in the whole organism at one dose (the size of the read-out at that dose, not a potency): 100%
The estimate for compound 3 lay 40 percentage points below the measured number; the measured number lies above the stated range.
By their numbers in this assay, from the lowest: compounds 2 and 1 (each within the scatter of the next); then compound 3.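

In this assay, going by these compounds alone, 2-hydroxycyclohexyl in place of 2-hydroxycyclopentyl on an amide-type nitrogen gives a number 33 percentage points higher from compound 1 to compound 3 (beyond the scatter) and is the only step that isolates a single change. This position therefore responds strongly to this change, which compounds 1 and 2 could not show, as they differ in more than one place. Nothing at hand accounts for the size of this step. Still open, from the compounds shown here alone, is whether 2-aminocyclohexyl or 2-hydroxycycloheptyl on this nitrogen would hold the gain, and whether other stereoisomers of 2-hydroxycyclohexyl would match compound 3 .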